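Extending the Amide Substituent in a Weak Inhibitor Pair

The source may report more compounds than this note shows. Statements on the series, on what has been measured and on what is new or still open speak of the compounds shown alone.

Of the compounds shown here, two have been measured in an assay on cells for inhibition of cyclic GMP-AMP synthase (Homo sapiens), read by fluorescence polarization, with a stated time of 1 h, in the presence of a further agent that is not named here; on this read-out higher numbers stand for weaker inhibition and lower numbers for stronger inhibition. Compound 1 `Oc1cc(-c2ccccc2)nc2nnnn12` gives 78000 nM in this assay. Compound 2 `CNC(=O)c1cnn2c(O)cc(-c3ccccc3)nc12` gives 125000 nM; the gap between its number and that of compound 1 lies within the scatter, so the two stand level. Compound 3 `O=C(NCCO)c1cnn2c(O)cc(-c3ccccc3)nc12` differs from compound 2 only by hydroxymethyl in place of hydrogen on a saturated chain carbon bound to an amide-type nitrogen. Among the measured compounds shown here, no measured pair shows what such a change does here, so no shift beyond the scatter is expected, and the expected step is a 1.1-fold lower number from compound 2 to compound 3 (0.06 log units; within the scatter). Compound 3 is accordingly estimated at 110000 nM, with a range from 40000 nM to 300000 nM.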

Compound 3, half-maximal inhibitory concentration: 15100 nM
For compound 3 the middle estimate is 7.3-fold (0.86 log units) above the measured one; measured number outside the range, below it.
By their numbers in this assay, from the lowest: compound 3; then compounds 1 and 2 (each within the scatter of the next).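

The amide substituent is not a silent position in this assay: going from methylcarbamoyl to (2-hydroxyethyl)carbamoyl gives an 8.3-fold lower number from compound 2 to compound 3 (0.92 log units; beyond the scatter), which is beyond the scatter. Among the compounds shown here, this is the first change in the set to separate two compounds, and it shows that hydroxymethyl on this saturated chain carbon can strengthen inhibition. No measurement at hand explains the size of this step. Going by these compounds, whether the hydroxyl or the added chain length carries the step stays open, and a plain ethyl amide would separate the two. Also open, on these data alone, is how a longer chain, or an amine or carboxylic acid at its end, would read.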